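The source may report more compounds than this note shows. Statements on the series, on what has been measured and on what is new or still open speak of the compounds shown alone.

Measured compounds:
- compound 1, `Oc1cccc(-c2cc(-c3ccncc3)nc(-c3ccccc3Cl)c2)c1`: "not determined" (no result reported)
- compound 2, `Oc1cccc(-c2cc(-c3ccco3)nc(-c3ccccc3Cl)c2)c1`: 2010 nM
- compound 3, `Oc1cccc(-c2cc(-c3ccc(Cl)cc3)nc(-c3ccsc3)c2)c1`: 11500 nM

In a functional assay on T47D cells (Homo sapiens) for cytotoxicity, read by CCK-8 assay and cell counting, with a stated time of 2 days (a lower number here means a stronger inhibitor, a higher number a weaker inhibitor), compound 2 gives 2010 nM and compound 3 gives 11500 nM. Compound 3 thus has the higher of the two reported numbers, and the gap between them lies beyond the usual scatter; compound 1 contributes no number.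

Compound 4, `Oc1cccc(-c2cc(-c3ccsc3)nc(-c3ccccc3Cl)c2)c1`, is not yet measured. It differs from compound 3 only in where the chlorine sits on one aryl group: 2-chlorophenyl in place of 4-chlorophenyl on an aromatic carbon. Compound 2 also carries a 2-chlorophenyl group and gives 2010 nM, so a somewhat lower number than compound 3 is expected for compound 4. The step of a 2.9-fold lower number from compound 3 to compound 4 (0.46 log units; beyond the scatter) is expected to be modest, in the direction of a stronger inhibitor. Compound 4 is expected to give about 4000 nM, within 1000 nM to 15000 nM.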

Compound 4, half-maximal inhibitory concentration: 2440 nM
For compound 4 the middle estimate is 1.6-fold (0.21 log units) above the measured one; the range from low to high includes it.
By their numbers in this assay, from the lowest: compounds 2 and 4 (each within the scatter of the next); then compound 3.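

In this assay moving the chlorine from 4-chlorophenyl to 2-chlorophenyl changes the result (a 4.7-fold lower number from compound 3 to compound 4 (0.67 log units; beyond the scatter)), so where the chlorine sits on this aryl group matters in this series. With 2-chlorophenyl kept in place, thiophen-3-yl in place of furan-2-yl makes no clear difference (a 1.2-fold higher number from compound 2 to compound 4 (0.08 log units; within the scatter)), so this assay does not separate these two rings. Nothing measured here explains either result.

From the compounds shown here alone, whether the chlorine itself is needed remains open. An amine or a carboxylic acid in its place on the same aryl group could test this.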